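The source may report more compounds than this note shows. Statements on the series, on what has been measured and on what is new or still open speak of the compounds shown alone.

Three compounds built on one shared core have been examined in an assay on isolated protein for inhibition of 2-Hydroxyacid oxidase 2 (Homo sapiens), tested at 10 uM; a higher number here means a stronger effect of the compound at the concentration tested, a lower number a weaker effect. Compound 1, with the structure `Cc1n[nH]c(C(=O)O)c1Cc1ccc(Oc2ccccc2)cc1`, gives 43% in this assay. Compound 2, with the structure `Cc1n[nH]c(C(=O)O)c1Cc1ccc2ccccc2n1`, gives 18%, and compound 3, with the structure `Cc1n[nH]c(C(=O)O)c1CCc1ccc(F)cc1`, gives 16%. Among these three numbers compound 1 stands highest; its nearest neighbour is compound 2, whose number lies beyond the usual scatter below it, and the furthest is compound 3, whose number lies still further below.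

Compound 4, with the structure `Cc1n[nH]c(C(=O)O)c1Cc1ccc(C#N)cc1`, has not yet been measured in this assay. It differs from compound 1 in one place: cyano in place of phenoxy on an aromatic carbon. A large group leaves and a small one enters at the same spot on the ring.

What can be expected rests only on these three measurements. Compound 1, carrying the phenoxy group, is the one standing apart, while the two compounds with other, smaller attachments beyond the core give the lower numbers. For that reason the step from compound 1 to compound 4 is expected to be downward and beyond the scatter, of about a number 25 percentage points lower from compound 1 to compound 4 (beyond the scatter). Compound 4 is therefore estimated to give 18% in this assay, with a likely range from 5% to 35%.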

Compound 4, a percentage reported as inhibition, at one concentration (the size of the read-out at that concentration, not a potency): 6%
Beside the measured number, compound 4's estimate is 12 percentage points above it; low and high end bracket the measured number.
By their numbers in this assay, from the lowest: compounds 4, 3 and 2 (each within the scatter of the next, the first and the last beyond it); then compound 1.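

Among these compounds, this pair is the first in the set to differ in one place only, so the group on this aromatic carbon can be judged directly: in this assay, cyano in place of phenoxy gives a number 37 percentage points lower from compound 1 to compound 4 (beyond the scatter), a large step. What is attached at this spot therefore clearly affects the read-out, and the read-out falls when the phenoxy group, with 7 heavy atoms and a six-membered aromatic ring, gives way to the cyano group, with 2 heavy atoms and no ring. Both groups count one hydrogen-bond acceptor and no donors, but the swap changes the atom count, the ring and the triple bond together, and no measurement here explains the drop.

This single pair cannot show which of those differences matters, and a methoxy group, which keeps the oxygen of phenoxy without its ring, or a phenyl group, which keeps a ring without the oxygen, would help to separate them. As far as these compounds go, it also remains open whether a larger group such as benzyloxy, or an amine at the same spot, would give a read-out above or below that of compound 1.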